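This account rests on a few compounds, and the source may have more. Where it says the series, first, only, none or still open, it means among the compounds named here.

Working notes on the series. Going by the values given here, compound 3 `CCOC(=O)C1=Cc2ccccc2OC1(OCc1cn(CC(=O)Nc2ccc(I)cc2Cl)nn1)C(F)(F)F` gives 26100 nM in a functional assay on HeLa cells (Homo sapiens) for inhibition, read by MTT assay, with a stated time of 24 h; a lower number here means a stronger inhibitor, a higher number a weaker inhibitor; on the numbers so far it stands second highest of three, with compound 2 `CCOC(=O)C1=Cc2ccccc2OC1(OCc1cn(-c2ccc(F)c(Cl)c2)nn1)C(F)(F)F` at 22700 nM as its nearest neighbour and compound 1 `CCOC(=O)C1=Cc2ccccc2OC1(OCc1cn(CC(=O)Nc2ccc(C)cc2)nn1)C(F)(F)F` at 67400 nM as its furthest. Compound 4 `CCOC(=O)C1=Cc2ccccc2OC1(OCc1cn(-c2cccc(OC)c2)nn1)C(F)(F)F` is the next to be measured; it differs from compound 3 by 3-methoxyphenyl in place of ((2-chloro-4-iodophenyl)carbamoyl)methyl on an aromatic nitrogen. Among the compounds with values here, two measured steps bear on exchanging a carbamoylmethyl arm for a directly attached aryl on that aromatic nitrogen: a 3.0-fold lower number from compound 1 to compound 2 (0.47 log units; beyond the scatter) and a 1.1-fold higher number from compound 2 to compound 3 (0.06 log units; within the scatter). One is modest, the other within scatter, so in this assay a small step toward a lower number, or none beyond the scatter, is expected. For compound 4 the expected result is 20000 nM, within 8000 nM to 50000 nM, which would mean a 1.3-fold lower number from compound 3 to compound 4 (0.12 log units; within the scatter).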

Compound 4, half-maximal inhibitory concentration: > 150000 nM
Compound 4 ended at the assay's limit; the forecaster's own chance of this, stated with the estimate: 10%; middle value at least 7.5-fold (0.87 log units) away from the limit.
By their numbers in this assay, from the lowest: compounds 2 and 3 (each within the scatter of the next); then compound 1. At a limit, above all of these: compound 4.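

In this assay the value of compound 4 is a limit, not a number: the limit of > 150000 nM in this assay, at which 1 of the 4 values shown sits. A directly attached aryl on the aromatic nitrogen does not by itself hold the level of compound 2, as the substituents on that aryl count: an at least 6.6-fold higher number from compound 2 to compound 4 (0.82 log units; beyond the scatter). Going by these compounds alone, the change also goes upward against both carbamoylmethyl arms, with an at least 5.7-fold higher number from compound 3 to compound 4 (0.75 log units; beyond the scatter) and an at least 2.2-fold higher number from compound 1 to compound 4 (0.34 log units; beyond the scatter), whereas the earlier compounds all stayed within the measurable range.

Still open, going by these compounds, is whether the methoxy group or the loss of the halogens of compound 2 carries this change. Also open, on these data alone, is how an aryl bearing an amine or a carboxylic acid would read at this place.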